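A few compounds are considered here, and "the series" means these few. Any claim that something is new, unique, unknown or untested is made for them only; others in the source may bear on it.

Measured in a functional assay on C8166 cells (Homo sapiens) for cytotoxicity, read by MTT assay, with a stated time of 72 h; on this read-out lower numbers stand for higher toxicity in this test and higher numbers for lower toxicity in this test:
- compound 1 `Cc1ccc(S(=O)(=O)N2CC3(C[C@H]2C(=O)N/N=C/c2ccccc2[N+](=O)[O-])SCCS3)cc1`: 65000 nM
- compound 2 `Cc1ccc(S(=O)(=O)N2CC3(C[C@H]2C(=O)N/N=C/c2ccccc2F)SCCS3)cc1`: 280000 nM
- compound 3 `Cc1ccc(S(=O)(=O)N2CC3(C[C@H]2C(=O)N/N=C/c2ccccc2Cl)SCCS3)cc1`: > 404000 nM (a limit, not a number)

Compound 3 stands at the limit of > 404000 nM in this assay, at which 1 of the 3 values shown sits, so it has a limit only.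

Next comes compound 4 `Cc1ccc(S(=O)(=O)N2CC3(C[C@H]2C(=O)N/N=C/c2cccc([N+](=O)[O-])c2)SCCS3)cc1`, with 3-nitrophenyl in place of 2-chlorophenyl on a carbon with a double bond to nitrogen. Among the measured compounds shown here, two measured steps bear on this change. Chloro in place of nitro gives an at least 6.2-fold higher number from compound 1 to compound 3 (0.79 log units; beyond the scatter), and fluoro in place of nitro gives a 4.3-fold higher number from compound 1 to compound 2 (0.63 log units; beyond the scatter). Both are modest, though the nitro group of compound 4 stands at a different place from that of compound 1. Read in reverse, they lead to the expectation of a modest step to a lower number in this assay. The expected change is an at least 4.0-fold lower number from compound 3 to compound 4 (0.60 log units; beyond the scatter). For compound 4 the estimate is 100000 nM, with an expected range of 35000 nM to 300000 nM.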

Compound 4, half-maximal cytotoxic concentration: > 395000 nM
Compound 4: a limit, no number (the forecaster's own chance of this, stated with the estimate: 20%); middle value at least 3.9-fold (0.59 log units) from the limit.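

In this assay compound 4 carries a limit, not a number: the limit of > 395000 nM in this assay, at which 1 of the 4 values shown sits.

3-nitrophenyl in place of 2-nitrophenyl gives an at least 6.0-fold higher number from compound 1 to compound 4 (0.78 log units; beyond the scatter), so among these compounds the lower number goes with 2-nitrophenyl and not with a nitro group as such. 3-nitrophenyl in place of 2-fluorophenyl gives an at least 1.4-fold higher number from compound 2 to compound 4 (0.14 log units; that floor lies within the scatter), while the step between compound 3 and compound 4 cannot be read.

On these data alone, how far the true values of compound 3 and compound 4 lie past their limits stays open. Also open, as far as these compounds go, is whether an amine or a carboxylic acid on the phenyl ring would give a measurable number.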